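The compounds below may be only part of what the source reports. "The series", "measured", "known", "first", "only" and "open" are said of these compounds alone.

In a functional assay on HGC-27 cells (Homo sapiens) for inhibition, read by MTT assay, with a stated time of 72 h (a lower number here means a stronger inhibitor, a higher number a weaker inhibitor), compound 2 `Cc1cc(N2CC[C@@H](C)[C@@H](N(C)c3ncnc4[nH]ccc34)C2)n2ncnc2n1` gives 11300 nM and compound 1 `Cc1cc(N2CC[C@@H](C)[C@@H](N(C)c3ncnc4[nH]ccc34)C2)n2nc(SCc3ccccc3)nc2n1` gives 13900 nM, two values within the scatter of each other. Compound 3 `C[C@@H]1CCN(c2cc(-c3ccccc3)nc3ncnn23)C[C@@H]1N(C)c1ncnc2[nH]ccc12` gives only a limit, > 100000 nM. Compound 4 `Cc1cc(N2CC[C@@H](C)[C@@H](N(C)c3ncnc4[nH]ccc34)C2)n2nc(SCc3ccccc3Br)nc2n1` differs from compound 2 as follows: (2-bromobenzyl)sulfanyl in place of hydrogen on an aromatic carbon. The closest guide is the loss of plain benzylsulfanyl at that carbon, a 1.2-fold lower number from compound 1 to compound 2 (0.09 log units; within the scatter), a step within the scatter. The other step, an at least 8.8-fold higher number from compound 2 to compound 3 (0.94 log units; beyond the scatter), concerns the methyl and not this carbon, so it bears little here. From the compounds shown here alone, the added bromine is untested, so no step beyond the scatter is expected in this assay. The expected step is a 1.1-fold lower number from compound 2 to compound 4 (0.05 log units; within the scatter). For compound 4 the estimated value is 10000 nM, within a range of 4000 nM to 30000 nM.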

Compound 4, half-maximal inhibitory concentration: 21300 nM
Compound 4: the middle estimate sits 2.1-fold (0.33 log units) below what was measured; measured number inside the range.
By their numbers in this assay, from the lowest: compounds 2, 1 and 4 (each within the scatter of the next). At a limit, above all of these: compound 3.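

At this carbon, between two ring nitrogen atoms, the (2-bromobenzyl)sulfanyl group joins plain benzylsulfanyl in staying within the scatter in this assay, with a 1.9-fold higher number from compound 2 to compound 4 (0.28 log units; within the scatter). Adding bromo to the benzyl ring also stays within the scatter, with a 1.5-fold higher number from compound 1 to compound 4 (0.19 log units; within the scatter), so in these compounds neither the sulfur-linked group nor its bromine separates the readings. Nothing measured here bears on this result. From the compounds shown here alone, whether an amine or a carboxylic acid at this carbon would give a step beyond the scatter stays open, as does the outcome for chloro or methoxy on the benzyl ring.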